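The compounds below may be only part of what the source reports. "The series", "measured", "known", "first", "only" and "open" are said of these compounds alone.

Measured so far:
- compound 1, `CN1CCN(c2ccc(Nc3ncc4nc(Nc5ccc(F)cc5)n([C@H]5CCCN(C(=O)CO)C5)c4n3)cc2)CC1`: 1.8 nM
- compound 2, `CN1CCN(c2ccc(Nc3ncc4nc(Nc5ccccc5)n([C@H]5CCN(C(=O)OC(C)(C)C)C5)c4n3)cc2)CC1`: 110 nM
- compound 3, `CN1CCN(c2ccc(Nc3ncc4nc(Nc5ccc(F)cc5)n([C@H]5CCN(C(=O)OC(C)(C)C)C5)c4n3)cc2)CC1`: 580 nM

In a functional assay on HCC827 cells (Homo sapiens) for antiproliferative activity, read by MTT assay, with a stated time of 72 h (on this read-out higher numbers stand for weaker inhibition and lower numbers for stronger inhibition), compound 2 gives 110 nM, the second highest of the three numbers; compound 3 lies a step above it, compound 1 far below. Compound 4, `CNC(=O)CN1CC[C@H](n2c(Nc3ccccc3)nc3cnc(Nc4ccc(N5CCN(C)CC5)cc4)nc32)C1`, differs from compound 2 only at the ring amine nitrogen: (methylcarbamoyl)methyl in place of tert-butoxycarbonyl on an amine nitrogen in a ring. The step that bears on this position is a 320-fold higher number from compound 1 to compound 3 (2.51 log units; beyond the scatter), where the tert-butoxycarbonyl replaced a smaller group carrying a hydrogen-bond donor; a 5.3-fold higher number from compound 2 to compound 3 (0.72 log units; beyond the scatter) concerns a different position and does not bear on it. A move away from tert-butoxycarbonyl is therefore expected to lower the number, as a 5.5-fold lower number from compound 2 to compound 4 (0.74 log units; beyond the scatter). Compound 4 is estimated at 20 nM, within 5 nM to 80 nM.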

Compound 4, half-maximal inhibitory concentration: 170 nM
For compound 4 the middle estimate is 8.5-fold (0.93 log units) below the measured one, outside the stated range (above it).
By their numbers in this assay, from the lowest: compound 1; then compounds 2 and 4 (each within the scatter of the next); then compound 3.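

With a 1.5-fold higher number from compound 2 to compound 4 (0.19 log units; within the scatter) in this assay there is no readable difference between (methylcarbamoyl)methyl and tert-butoxycarbonyl on this amine nitrogen in the five-membered ring. Bringing a hydrogen-bond donor onto this nitrogen is therefore not enough on its own to match a 320-fold higher number from compound 1 to compound 3 (2.51 log units; beyond the scatter) as a change, and that larger step also swaps the piperidin-3-yl ring for the pyrrolidin-3-yl ring. Nothing measured here explains this result.

Still open, on these data alone, is how much of that larger step belongs to the ring and how much to the group on its nitrogen. Also open, as far as these compounds go, is how a hydroxyacetyl group, a longer chain or a chain ending in a carboxylic acid would read on this pyrrolidine nitrogen.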